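This account rests on a few compounds, and the source may have more. Where it says the series, first, only, none or still open, it means among the compounds named here.

In a functional assay on RT-112 cells (Homo sapiens) for antiproliferative activity, read by MTT assay, with a stated time of 72 h (a higher number here means a weaker inhibitor of growth, a lower number a stronger inhibitor of growth), compound 1 `COc1cc(NC(=O)Nc2cccc3c(Nc4cc(OC)cc(OC)c4)ncnc23)cc(OC)c1` gives 366 nM, compound 2 `COc1cc(Nc2ncnc3c(NC(=O)Nc4ccc(C)c(C)c4)cccc23)cc(OC)c1` gives 8.8 nM and compound 3 `COc1cc(Nc2ncnc3c(NC(=O)Nc4ccc(F)cc4F)cccc23)cc(OC)c1` gives 2460 nM, so compound 3 is the weakest of the three. Compound 4 `COc1cc(Nc2ncnc3c(NC(=O)c4cc(=O)c5ccccc5o4)cccc23)cc(OC)c1` differs from it at one place: a group of 11 heavy atoms (9 carbon, 2 oxygen; one six-membered aromatic ring of carbon only, one six-membered aromatic ring with 1 hetero atom) in place of a group of 9 heavy atoms (6 carbon, 1 nitrogen, 2 fluorine; one six-membered aromatic ring of carbon only), on a carbonyl carbon. Swapping the group on the amide-type nitrogen has already moved the numbers widely, with a 42-fold lower number from compound 1 to compound 2 (1.62 log units; beyond the scatter), a 6.7-fold higher number from compound 1 to compound 3 (0.83 log units; beyond the scatter) and a 280-fold higher number from compound 2 to compound 3 (2.45 log units; beyond the scatter). For the measured compounds named here, none of these steps brought in a group like the new one, so they show sensitivity but give no direct precedent. With compound 3 at the top of the range at 2460 nM, a modest move to a lower number in this assay is more likely than a further rise. The expected change is a 3.5-fold lower number from compound 3 to compound 4 (0.55 log units; beyond the scatter). For compound 4 the estimated value is 700 nM, with an expected range from 120 nM to 4000 nM.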

Compound 4, concentration for 50% growth inhibition: > 20000 nM
Compound 4 was reported as a limit; the forecaster's own chance of this, stated with the estimate: 5%; middle value at least 28-fold (1.45 log units) away from the limit.
By their numbers in this assay, from the lowest: compound 2; then compound 1; then compound 3. At a limit, above all of these: compound 4.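

Compound 4 is reported only as a limit, > 20000 nM, in this assay. The two-ring group on the carbonyl carbon brings an at least 8.1-fold higher number from compound 3 to compound 4 (0.91 log units; beyond the scatter), along with an at least 54-fold higher number from compound 1 to compound 4 (1.73 log units; beyond the scatter) and an at least 2200-fold higher number from compound 2 to compound 4 (3.35 log units; beyond the scatter), so this position can lose growth inhibition almost entirely, not merely shift it. Compounds 1, 2 and 3 all keep an amino nitrogen and a single-ring aryl group here, whereas compound 4 has neither the nitrogen nor its hydrogen-bond donor.

The compounds shown do not separate losing that nitrogen from adding the second ring. A plain phenyl on the carbonyl carbon, or the same two-ring group attached through an amino nitrogen, would bear on that question.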